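Replacing the 6-fluoropyridin-3-yl group of compound 1

This account rests on a few compounds, and the source may have more. Where it says the series, first, only, none or still open, it means among the compounds named here.

Measured in an ADME assay on MRC5 cells (Homo sapiens) for cytotoxicity, read by resazurin assay, with a stated time of 72 h; on this read-out lower numbers stand for stronger inhibition and higher numbers for weaker inhibition:
compound 1 `CC1(COc2ncc(-c3ccc(F)nc3)cn2)CCn2cc([N+](=O)[O-])nc2O1`: > 64000 nM
compound 2 `CC1(COc2cccc(-c3ccc(F)nc3)n2)CCn2cc([N+](=O)[O-])nc2O1`: > 64000 nM

For the measured compounds named here, the only reading of compound 1 is > 64000 nM and this is a limit of the assay, not a number. Compound 2 gives > 64000 nM and this too is a limit. Going by the values given here, the series so far offers the limit of > 64000 nM in this assay, at which 2 of the 2 values shown sit, and no measured step to scale from.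

Compound 3 `CC1(COc2ncc(-c3ccc(F)cc3)cn2)CCn2cc([N+](=O)[O-])nc2O1` keeps the core of compound 1 and carries 4-fluorophenyl in place of 6-fluoropyridin-3-yl. The change is 4-fluorophenyl in place of 6-fluoropyridin-3-yl on an aromatic carbon and it falls on an aromatic carbon of a six-membered aromatic ring with 2 nitrogen, para to a large group.

Because of the limit of > 64000 nM in this assay, at which 2 of the 2 values shown sit, only a small step is expected in this assay and any movement would be toward stronger inhibition, possibly none beyond the scatter. The estimated change is an at least 1.1-fold lower number from compound 1 to compound 3 (0.06 log units; that floor lies within the scatter) and it remains a rough expectation. For compound 3 the expected value is 55000 nM with an estimated range from 22000 nM to 64000 nM and another limit reading is quite possible.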

Compound 3, half-maximal inhibitory concentration: 57000 nM
Compound 3: the middle estimate sits 1.0-fold (0.02 log units) below what was measured, and the stated range covers the measured number.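

For the compounds shown here, compound 3 is the first compound here to give a number rather than a limit in this assay: compound 3 gives 57000 nM. At this position on the shared core, on an aromatic carbon of a six-membered aromatic ring with 2 nitrogen, putting 4-fluorophenyl in place of 6-fluoropyridin-3-yl gives an at least 1.1-fold lower number from compound 1 to compound 3 (0.05 log units; that floor lies within the scatter). The step can be read only as a floor, since the reading of compound 1 is a limit, so the data show neither a real gap between the two compounds nor its absence: the limit of > 64000 nM in this assay, at which 2 of the 3 values shown sit.

On these data alone, whether the ring nitrogen of 6-fluoropyridin-3-yl has any bearing on this read-out remains open, since the true value of compound 1 lies out of reach of the assay and compound 3 differs from compound 2 in more than one place. Also open is how a morpholine, a carboxylic acid or a trifluoromethoxy group on the outer aromatic ring would read in this assay, as every compound shown carries a single fluorine there.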